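A few compounds are considered here, and "the series" means these few. Any claim that something is new, unique, unknown or untested is made for them only; others in the source may bear on it.

Working notes on the series. Within the data shown here, compound 3 `O=C(Nc1ccccc1C(F)(F)F)C1CCc2ccccc2N1C(=O)c1ccc(Cl)cc1` gives the only number in the set: in a functional assay on MDA-MB-231 cells (Homo sapiens) for cytotoxicity, read by sulforhodamine B assay, with a stated time of 72 h (a higher number here means a weaker inhibitor of growth, a lower number a stronger inhibitor of growth), compound 3 gives 533 nM. Compound 1 `CCCC(=O)N1c2ccccc2CCC1C(=O)Nc1ccccc1C(F)(F)F` reaches only a limit in this assay, > 70000 nM. Compound 2 `CCC(=O)N1c2ccccc2CCC1C(=O)Nc1ccccc1C(F)(F)F` likewise reaches only a limit in this assay, > 80000 nM. Compound 1 sits at the limit of > 70000 nM in this assay, at which 1 of the 3 values shown sits. Compound 2 sits at the limit of > 80000 nM in this assay, at which 1 of the 3 values shown sits. Because of these two limits, the step that the two limits leave unreadable from compound 1 to compound 2 cannot be read, and propyl against ethyl on that carbonyl carbon is not separable here.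

Compound 4 `CC(=O)N1c2ccccc2CCC1C(=O)Nc1ccccc1C(F)(F)F` has not been measured. It differs from compound 3 by methyl in place of 4-chlorophenyl on a carbonyl carbon. The measured steps that bear on this run in the opposite direction: an at least 130-fold lower number from compound 1 to compound 3 (2.11 log units; beyond the scatter) and an at least 150-fold lower number from compound 2 to compound 3 (2.17 log units; beyond the scatter), each starting from a short alkyl group on the same carbonyl carbon. Returning to a short alkyl, now methyl, a large rise in this assay is therefore expected, a 190-fold higher number from compound 3 to compound 4 (2.27 log units; beyond the scatter), most likely back to a limit. Compound 4 is expected at 100000 nM, in the range 20000 nM to 400000 nM, with a strong chance that only a limit is reported.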

Compound 4, concentration for 50% growth inhibition: > 80000 nM
Compound 4 ended at the assay's limit; the forecaster's own chance of this, stated with the estimate: 80%; the middle value lies beyond the limit too.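

With methyl on this carbonyl carbon, the short-alkyl side of the comparison now spans propyl, ethyl and methyl, and none of the three gives a number in this assay. The step of an at least 150-fold higher number from compound 3 to compound 4 (2.17 log units; beyond the scatter) is the widest change in the group on this carbon so far, and it extends the loss seen with propyl and ethyl to the smallest of the alkyl groups, so chain length among these three does not recover a number. Compound 4 gives a limit, not a number, and the steps linking compound 1, compound 2 and compound 4 cannot be read: the limit of > 80000 nM in this assay, at which 2 of the 4 values shown sit.

Only compound 3 gives a number, so the series does not separate the chlorine from the aromatic ring of 4-chlorophenyl. Plain phenyl, 4-fluorophenyl and cyclohexyl on this carbonyl carbon would address that question, and a longer chain such as hexyl would test the alkyl side.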